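The source may report more compounds than this note shows. Statements on the series, on what has been measured and on what is new or still open speak of the compounds shown alone.

Measured in an ADME assay on microsomes from liver (Rattus norvegicus) for metabolic stability; on this read-out lower numbers stand for a shorter-lived compound and higher numbers for a longer-lived compound:
- compound 1 `CC(C)C(Cc1ncc[nH]1)c1ccc(-c2ccc3cccc(F)c3c2)[nH]c1=O`: < 0.0667 h (a limit)
- compound 2 `CC(C)C(c1ccc(-c2ccc3cccc(F)c3c2)[nH]c1=O)N1CCN/C1=N\C#N`: 0.327 h
- compound 3 `CC(C)C(c1noc(=O)[nH]1)c1ccc(-c2ccc3cccc(F)c3c2)[nH]c1=O`: > 3 h (a limit)

Compound 3 stands at the long-lived end of these three. Its entry of > 3 h is a limit and not a number. Compound 4 `CC(C)NC(=O)CC(c1ccc(-c2ccc3cccc(F)c3c2)[nH]c1=O)C(C)C` keeps the shared core and changes one group: a group of 7 heavy atoms (5 carbon, 1 nitrogen, 1 oxygen; no ring) in place of a group of 6 heavy atoms (2 carbon, 2 nitrogen, 2 oxygen; one five-membered aromatic ring with 3 hetero atoms), on a saturated chain carbon bound to an aromatic carbon and a saturated chain carbon. The measured steps bearing on this all involve the same place. They are an at least 44-fold higher number from compound 1 to compound 3 (1.65 log units; beyond the scatter), which is large, an at least 9.1-fold higher number from compound 2 to compound 3 (0.96 log units; beyond the scatter) and an at least 4.9-fold higher number from compound 1 to compound 2 (0.69 log units; beyond the scatter), and all three lie beyond the scatter. Within the data shown here, neither group measured as an alternative to the one in compound 3 retains its stability, as an at least 9.1-fold higher number from compound 2 to compound 3 (0.96 log units; beyond the scatter) shows for the nearer of the two. Among the measured compounds shown here, compound 4 also gives up that ring, although no measured compound carries an open chain here. A clear fall in this assay is therefore expected, of modest to large size, and the expected step is an at least 10-fold lower number from compound 3 to compound 4 (1.00 log units; beyond the scatter). For compound 4 the estimated half-life is 0.3 h, with an expected range of 0.07 h to 1.5 h.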

Compound 4, half-life: < 0.0667 h
Compound 4: no number, only a limit; the forecaster's own chance of this, stated with the estimate: 20%; middle value at least 4.4-fold (0.65 log units) from the limit.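

In this assay, among these compounds, the open chain brings the first ring-free group to this saturated chain carbon, and it gives an at least 44-fold lower number from compound 3 to compound 4 (1.65 log units; beyond the scatter) as well as an at least 4.9-fold lower number from compound 2 to compound 4 (0.69 log units; beyond the scatter). Across the four groups shown, only the five-membered aromatic ring with 3 hetero atoms in compound 3 reaches the long-lived end, while the open chain of compound 4 falls to the short-lived end, so the position does not tolerate just any group with a hydrogen-bond donor and a carbonyl. The step between compound 1 and compound 4 cannot be read, as both stand at one limit: the limit of < 0.0667 h in this assay, at which 2 of the 4 values shown sit.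

On these data alone, it remains open whether a carboxylic acid, an amine or a longer chain on this carbon would keep the half-life of compound 3. Also open, as far as these compounds go, is whether an amide held in a ring, rather than the (isopropylcarbamoyl)methyl chain, would recover any of it.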